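Fixing Both Ring Stereocentres: From Compound 3 to Compound 4

The source may hold more compounds than are shown below. What is called first, only, known or untested is meant among the compounds shown, and "the series" means these compounds.

Among the two numbers measured in an ADME assay on MT4 cells (Homo sapiens) for cytotoxicity, read by XTT assay, with a stated time of 3 days (on this read-out higher numbers stand for lower toxicity in this test and lower numbers for higher toxicity in this test), compound 3 `CC(C)c1c(OC2CCCCC2C)cc(CCc2ccccc2)[nH]c1=O` holds the highest, giving 201000 nM. Its nearest neighbour is compound 1 `COc1ccc(Cc2cc(OC3CCCCC3C)c(C(C)C)c(=O)[nH]2)cc1`, which gives 74500 nM, with a 2.7-fold higher number from compound 1 to compound 3 (0.43 log units; beyond the scatter) on exchanging benzyl for 4-methoxyphenyl. Compound 2 `CC(C)c1c(O[C@H]2CCCC[C@@H]2C)cc(CCc2ccccc2)[nH]c1=O` reaches only a limit of this assay, giving > 300000 nM. Compound 4 `CC(C)c1c(O[C@H]2CCCC[C@H]2C)cc(CCc2ccccc2)[nH]c1=O` differs from compound 3 in that (the two compounds have the same atoms and bonds; at least one stereo element is drawn with a configuration in one of them and without one in the other: 2 of 2 stereo elements differ; a stereocentre at a saturated ring carbon is drawn without a configuration in compound 3 and S in compound 4; a stereocentre at a saturated ring carbon is drawn without a configuration in compound 3 and R in compound 4). Among the compounds with values here, the one step that bears on this change is the stereochemical one, an at least 1.4-fold lower number from compound 2 to compound 3 (0.17 log units; that floor lies within the scatter), which stays within the scatter, so defining the configuration is expected to bring no step beyond the scatter: a 1.0-fold lower number from compound 3 to compound 4 (0.00 log units; within the scatter). Compound 4 is therefore estimated at 200000 nM, in a range from 100000 nM to 300000 nM.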

Compound 4, half-maximal cytotoxic concentration: 87900 nM
Compound 4: the middle estimate sits 2.3-fold (0.36 log units) above what was measured; the whole stated range lies above it.
By their numbers in this assay, from the lowest: compounds 1 and 4 (each within the scatter of the next); then compound 3. At a limit, above all of these: compound 2.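

In this assay, the two ring stereocentres turn out not to be interchangeable: changing one from S to R gives an at least 3.4-fold lower number from compound 2 to compound 4 (0.53 log units; beyond the scatter). That change is purely one of configuration: the fact that compounds 2 and 4 differ only in the configuration as drawn Drawing both centres also shifts the number relative to the undefined compound, with a 2.3-fold lower number from compound 3 to compound 4 (0.36 log units; beyond the scatter).

Going by these compounds, compound 2 gives > 300000 nM, which is a limit, so the full size of that step stays open. Also open, on these data alone, is whether configuration would matter as much with a carboxylic acid in place of the methyl group on the ring.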